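The source may hold more compounds than are shown below. What is called first, only, known or untested is meant among the compounds shown, and "the series" means these compounds.

Compound 1 `O=c1nc(-c2ccccc2)c2cc(-c3cccnc3)ccc2[nH]1` was tested in an ADME assay on THP-1 cells (Homo sapiens) for cytotoxicity, read by MTT assay, with a stated time of 72 h; on this read-out lower numbers stand for an effect already at smaller amounts and higher numbers for an effect only at larger amounts of compound; in it compound 1 gives > 50000 nM, which is a limit of the assay rather than a number. Compound 2 `Cc1ccc(-c2ccc3[nH]c(=O)nc(-c4ccccc4)c3c2)cn1` gives > 50000 nM, also a limit. Compound 3 `Cc1cncc(-c2ccc3[nH]c(=O)nc(-c4ccccc4)c3c2)c1` gives > 50000 nM, again a limit.

Compound 3 therefore stands at the limit shared by all three measured compounds (the limit of > 50000 nM in this assay, at which 3 of the 3 values shown sit). The change to compound 4 `O=c1nc(-c2ccccc2)c2cc(-c3ccccc3)ccc2[nH]1` is phenyl in place of 5-methylpyridin-3-yl on an aromatic carbon. The measured steps that bear on it are a step that the two limits leave unreadable from compound 1 to compound 2, a step that the two limits leave unreadable from compound 1 to compound 3 and a step that the two limits leave unreadable from compound 2 to compound 3, none of which can be sized, since each starts and ends at a limit. Nothing in these data points to an effect within the measured range, so compound 4 is expected to sit where the others do. The estimate for compound 4 is 70000 nM, with a range from 30000 nM to 250000 nM, and the expected step is a step that the limit leaves unreadable from compound 3 to compound 4.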

Compound 4, half-maximal effective concentration: > 50000 nM
Compound 4: a limit, no number (the forecaster's own chance of this, stated with the estimate: 80%); the middle value is on the limit's open side.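

The steps joining compound 4 to compound 1, compound 2 and compound 3 cannot be read in this assay, since each runs between two limits: the limit of > 50000 nM in this assay, at which 4 of the 4 values shown sit.

The compounds shown leave open whether any change to the shared core would give a value within the measured range.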